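A Sulfur Atom Gives Way to a Selenium Chain

The source may report more compounds than this note shows. Statements on the series, on what has been measured and on what is new or still open speak of the compounds shown alone.

Compound 3 `Sc1nc(NCc2ccccc2)c2ccccc2n1` carries a sulfanyl group on its fused core. In a functional assay on HT-29 cells (Homo sapiens) for cytotoxicity, read by MTT assay, with a stated time of 72 h (a lower number here means that less compound is tolerated, a higher number that more compound is tolerated), compound 3 gives > 100000 nM, which is a limit of the assay rather than a number. Two related compounds were measured alongside it. Compound 1 `CCCCC[Se]c1nc(NCc2ccc(SC)cc2)c2ccccc2n1` gives > 100000 nM in this assay, again a limit. Compound 2 `CCCCC[Se]c1nc([Se]CCCCC)c2ccccc2n1` gives > 100000 nM in this assay, also a limit. Compound 3 thus stands exactly where the other two measured compounds stand, because the limit of > 100000 nM in this assay, at which 3 of the 3 values shown sit, marks the point at which every value sits.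

Compound 4 `CCCCC[Se]c1nc(NCc2ccccc2)c2ccccc2n1` differs from compound 3 in one place: a group of 6 heavy atoms (5 carbon, 1 selenium; no ring) in place of one sulfur atom, on an aromatic carbon. Going by the values given here, no step between two measured compounds is available, so any expectation for the size of this step rests on the three limits alone. With every measured value sitting at the limit, compound 4 is expected to remain at that limit, with no change beyond the scatter, and the step of a number no higher from compound 3 to compound 4 (the limit leaves the size open) expresses that expectation. Compound 4 is therefore estimated at 100000 nM, with a range from 40000 nM to 300000 nM.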

Compound 4, concentration lethal to 50% of the cells: > 100000 nM
Compound 4: no number, only a limit; the forecaster's own chance of this, stated with the estimate: 85%; the middle value lies on the limit itself.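

Going by these compounds alone, no step from compound 1, compound 2 or compound 3 to compound 4 can be read, because all four values are limits: the limit of > 100000 nM in this assay, at which 4 of the 4 values shown sit.

The compounds shown leave open whether any of the four differs from the others in this assay, and by how much.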